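A Bromo Swap Repeated on a Second Core

The source may hold more compounds than are shown below. What is called first, only, known or untested is meant among the compounds shown, and "the series" means these compounds.

Compound 1 `COc1ccc(C2CC(c3ccccc3)=NN2C2=NC(=O)/C(=C3\C(=O)Nc4ccccc43)S2)cc1` is the starting point of the set. In a functional assay on cells (Cancer cell lines, Homo sapiens) for cytotoxicity, read by sulforhodamine B assay, with a stated time of 48 h (a higher number here means a weaker inhibitor of growth, a lower number a stronger inhibitor of growth), compound 1 gives 1810 nM. Compound 2 `COc1ccc(C2CC(c3ccccc3)=NN2C2=NC(=O)/C(=C3\C(=O)Nc4ccc(Br)cc43)S2)cc1` carries a single change, (bromo in place of hydrogen on an aromatic carbon), and in this assay compound 2 gives 190 nM, so the step of a 9.5-fold lower number from compound 1 to compound 2 (0.98 log units; beyond the scatter) points toward stronger growth inhibition. Compound 3 `COc1ccc(C2=NN(C3=NC(=O)/C(=C4\C(=O)Nc5ccccc54)S3)C(c3ccc(Cl)cc3)C2)cc1` rests on a different core, and the difference between the two cores is not broken down here. In this assay compound 3 gives 100000 nM, the highest of the three measured numbers. Compound 4 `COc1ccc(C2=NN(C3=NC(=O)/C(=C4\C(=O)Nc5ccc(Br)cc54)S3)C(c3ccc(Cl)cc3)C2)cc1` has not yet been measured. It differs from compound 3 by bromo in place of hydrogen on an aromatic carbon, the same change that turned compound 1 into compound 2. Because a 9.5-fold lower number from compound 1 to compound 2 (0.98 log units; beyond the scatter) lay beyond the scatter, a lower number is expected here too, though the very weak starting point of compound 3 leaves the size open, so for compound 4 the expected step is a 5.0-fold lower number from compound 3 to compound 4 (0.70 log units; beyond the scatter). The estimate for compound 4 in this assay is 20000 nM, expected to fall between 4000 nM and 100000 nM.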

Compound 4, concentration for 50% growth inhibition: 130 nM
Beside the measured number, compound 4's estimate is 150-fold (2.19 log units) above it, outside the stated range (below it).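

On both cores, bromo in place of hydrogen on an aromatic carbon gives a lower number, and in this assay the new step is a 770-fold lower number from compound 3 to compound 4 (2.89 log units; beyond the scatter) and is large. So the direction of the change carries from one core to the other in these two pairs, but its size does not: the same change on two cores in this assay, a 9.5-fold lower number (0.98 log units; beyond the scatter) from compound 1 to compound 2 and a 770-fold lower number (2.89 log units; beyond the scatter) from compound 3 to compound 4, 81-fold (1.91 log units) apart, beyond the scatter of two such steps

What this does not show is which difference between the core of compound 1 and the core of compound 3 lies behind that gap, and two pairs cannot tell how large the step would be on any third core.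

The compounds shown leave open whether bromo itself matters or whether another group on the same aromatic carbon, such as fluoro, chloro, methyl or an amine, would lower the number as well. For the compounds shown here, they also leave open whether the step depends on this particular aromatic carbon, since bromo stands at only one place on that ring.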